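The source may hold more compounds than are shown below. What is called first, only, known or untested is meant among the compounds shown, and "the series" means these compounds.

Compound 1 `c1ccc(-c2cccc3c2CCC3c2ncc[nH]2)nc1`; in a functional assay on CHO cells for agonist activity at Alpha-1A adrenergic receptor (Homo sapiens), read by FLIPR and calcium flux (on this read-out lower numbers stand for an effect already at smaller amounts and higher numbers for an effect only at larger amounts of compound), compound 1 gives 1150 nM.
Compound 2 `COc1c(C)ccc2c1CCC2c1ncc[nH]1`; in this assay compound 2 gives 167 nM.
Compound 3 `CCCS(=O)(=O)Nc1cccc2c1CCC2c1ncc[nH]1`; in this assay compound 3 gives 1340 nM.

Compound 3 has the highest of the three numbers; compound 1 lies nearest, within the scatter, while compound 2 lies furthest, beyond it. Compound 4 `Cn1nccc1-c1cccc2c1CCC2c1ncc[nH]1` differs from compound 3 by 1-methyl-1H-pyrazol-5-yl in place of (propylsulfonyl)amino on an aromatic carbon. Within the data shown here, the one measured step that bears on this exchange is a 1.2-fold higher number from compound 1 to compound 3 (0.07 log units; within the scatter), where pyridin-2-yl on an aromatic carbon gave way to (propylsulfonyl)amino without a shift beyond the scatter. Compound 4 again carries an aromatic ring at that aromatic carbon, so the exchange is expected to bring no step beyond the scatter in this assay. Compound 4 is therefore estimated at 1100 nM, between 400 nM and 3000 nM, which is expected to mean a 1.2-fold lower number from compound 3 to compound 4 (0.09 log units; within the scatter).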

Compound 4, half-maximal effective concentration: 278 nM
Compound 4: the middle estimate sits 4.0-fold (0.60 log units) above what was measured; the measured number lies below the stated range.
By their numbers in this assay, from the lowest: compounds 2 and 4 (each within the scatter of the next); then compounds 1 and 3 (each within the scatter of the next).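

In this assay this aromatic carbon proves sensitive to what it carries: 1-methyl-1H-pyrazol-5-yl in place of (propylsulfonyl)amino brings a 4.8-fold lower number from compound 3 to compound 4 (0.68 log units; beyond the scatter), and in place of pyridin-2-yl it brings a 4.1-fold lower number from compound 1 to compound 4 (0.62 log units; beyond the scatter). Among these compounds, the earlier exchange at this carbon had stayed within the scatter, so the first step beyond it at this place comes with the pyrazolyl group, and two aromatic substituents no longer read alike. No evidence at hand accounts for this step. Open, as far as these compounds go, is whether the ring methyl matters, and how an unmethylated 1H-pyrazol-5-yl, a phenyl or an amine would read at this carbon.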